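The compounds below may be only part of what the source reports. "The series", "measured", "known", "first", "only" and "open" are said of these compounds alone.

Compound 3 `NC(=O)/C=C/c1cccc(C(F)(F)F)c1` gives 23.2 mg/kg in a functional assay on the whole organism with Mus musculus as the target; on this read-out higher numbers stand for an effect only at larger amounts of compound and lower numbers for an effect already at smaller amounts. Compound 1 `C/C(=C\c1cccc(C(F)(F)F)c1)C(N)=O` gives 22.4 mg/kg, and compound 2 `C/C(=C\c1cccc(C(F)(F)F)c1)C(=O)NC1CC1` gives 24.1 mg/kg; all three numbers lie within the scatter of one another, so no ranking among them can be drawn. Compound 4 `O=C(/C=C/c1cccc(C(F)(F)F)c1)NC1CC1` differs from compound 3 by cyclopropyl in place of hydrogen on an amide-type nitrogen. For the measured compounds named here, the only measured step of the same kind, a 1.1-fold higher number from compound 1 to compound 2 (0.03 log units; within the scatter), left the number essentially unchanged. Because a 1.1-fold higher number from compound 1 to compound 2 (0.03 log units; within the scatter) stayed within the scatter, compound 4 is expected to give a number close to that of compound 3. The step of a 1.0-fold higher number from compound 3 to compound 4 (0.01 log units; within the scatter) is therefore expected to stay within the scatter, in neither direction. The estimate for compound 4 is 24 mg/kg, with a range from 14 mg/kg to 40 mg/kg.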

Compound 4, dose for half-maximal effect: 9.6 mg/kg
Compound 4: middle estimate off by 2.5-fold (0.40 log units), on the high side, and the stated range ends above it.
By their numbers in this assay, from the lowest: compound 4; then compounds 1, 3 and 2 (each within the scatter of the next).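

In this assay, cyclopropyl in place of hydrogen on an amide-type nitrogen does not always leave the number unchanged: the change gives a 2.4-fold lower number from compound 3 to compound 4 (0.38 log units; beyond the scatter), so a smaller dose is enough for the effect. The two cores therefore need not respond alike, yet with one pair on each, their steps cannot be told apart firmly: the same change on two cores in this assay, a 1.1-fold higher number (0.03 log units; within the scatter) from compound 1 to compound 2 and a 2.4-fold lower number (0.38 log units; beyond the scatter) from compound 3 to compound 4, 2.6-fold (0.41 log units) apart, within the scatter of two such steps. The compounds shown leave open how a cyclobutyl ring, an ethyl group or a longer chain on this nitrogen would compare with cyclopropyl.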